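This account rests on a few compounds, and the source may have more. Where it says the series, first, only, none or still open, it means among the compounds named here.

In a functional assay on HCT-15 cells (Homo sapiens) for inhibition, read by MTT assay, with a stated time of 72 h (a higher number here means a weaker inhibitor, a lower number a stronger inhibitor), compound 3 `COc1cc(Oc2cccc(Nc3ccccc3)c2)cc(OC)c1CCO` gives 12100 nM, the highest number of the three measured; compound 1 `COc1cc(Oc2cccc(Nc3ccccc3)c2)cc(OC)c1CNCc1ccc(C)cc1` gives 5400 nM and compound 2 `CCN1CCN(Cc2c(OC)cc(Oc3cccc(Nc4ccccc4)c3)cc2OC)CC1` gives 5090 nM. The steps into compound 3 were a 2.2-fold higher number from compound 1 to compound 3 (0.35 log units; beyond the scatter) and a 2.4-fold higher number from compound 2 to compound 3 (0.38 log units; beyond the scatter), both modest, while a 1.1-fold lower number from compound 1 to compound 2 (0.03 log units; within the scatter). Compound 4 `COc1cc(Oc2cccc(Nc3ccccc3)c2)cc(OC)c1CNCc1ccc(O)cc1` carries (4-hydroxybenzyl)amino in place of hydroxymethyl on a saturated chain carbon bound to an aromatic carbon. This largely undoes the change measured as a 2.2-fold higher number from compound 1 to compound 3 (0.35 log units; beyond the scatter), the benzyl ring now bearing a hydroxyl where compound 1 bears a methyl, so a modest move back toward the number of compound 1 is expected rather than anything larger. In this assay compound 4 is therefore expected to give 5500 nM, in the range 2500 nM to 12000 nM. From compound 3 the expected step is a 2.2-fold lower number from compound 3 to compound 4 (0.34 log units; beyond the scatter).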

Compound 4, half-maximal inhibitory concentration: 3430 nM
Compound 4: the middle estimate sits 1.6-fold (0.21 log units) above what was measured; low and high end bracket the measured number.
By their numbers in this assay, from the lowest: compounds 4, 2 and 1 (each within the scatter of the next); then compound 3.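

In this assay, (4-hydroxybenzyl)amino on a saturated chain carbon bound to an aromatic carbon gives a 3.5-fold lower number from compound 3 to compound 4 (0.55 log units; beyond the scatter) and leaves compound 3, with hydroxymethyl, alone at the high end. Hydroxy in place of methyl on an aromatic carbon gives only a 1.6-fold lower number from compound 1 to compound 4 (0.20 log units; within the scatter) within the scatter, and (4-hydroxybenzyl)amino in place of 4-ethylpiperazin-1-yl gives a 1.5-fold lower number from compound 2 to compound 4 (0.17 log units; within the scatter) also within the scatter, so these three nitrogen-bearing groups cannot be ordered. No measurement available here explains these results.

Open, as far as these compounds go, is whether a carboxylic acid or an unsubstituted primary amine at this position would sit with compound 3 or with compound 4. Also open, from the compounds shown here alone, is how a longer chain between the nitrogen and the benzyl ring would read.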